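The source may report more compounds than this note shows. Statements on the series, on what has been measured and on what is new or still open speak of the compounds shown alone.

Working notes on the boronic-acid amide series. Compound 1 `O=C(CCc1cccc2c1B(O)OC2)NC1CCCCC1` in an ADME assay on WI-38 cells (Homo sapiens) for cytotoxicity, read by MTT assay, with a stated time of 72 h (a higher number here means a weaker inhibitor, a lower number a stronger inhibitor), gives > 100000 nM, which is a limit of the assay and not a number. Compound 2 `O=C(CCc1cccc2c1B(O)OC2)Nc1nccs1` in this assay gives > 100000 nM, again a limit. For the measured compounds named here, compound 3 `O=C(CCc1cccc2c1B(O)OC2)Nc1cccc(I)c1` in this assay gives 71000 nM, the only plain number among the three. Two of the three values thus sit at the assay ceiling (the limit of > 100000 nM in this assay, at which 2 of the 3 values shown sit). The step of an at least 1.4-fold lower number from compound 1 to compound 3 (0.14 log units; that floor lies within the scatter) and the step of an at least 1.4-fold lower number from compound 2 to compound 3 (0.14 log units; that floor lies within the scatter) have floors within the scatter, and the step that the two limits leave unreadable from compound 1 to compound 2 cannot be read. Compound 4 `CC(=O)c1cccc(-c2cccc(NC(=O)CCc3cccc4c3B(O)OC4)c2)c1` differs from compound 3 by 3-acetylphenyl in place of iodo on an aromatic carbon. Going by the values given here, none of the measured steps alters this ring, so no shift beyond the scatter is expected; the expected step is a 1.0-fold lower number from compound 3 to compound 4 (0.01 log units; within the scatter). Compound 4 is estimated at 70000 nM, between 25000 nM and 200000 nM.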

Compound 4, half-maximal inhibitory concentration: 2200 nM
For compound 4 the middle estimate is 32-fold (1.50 log units) above the measured one, outside the stated range (below it).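

Setting 3-acetylphenyl in place of iodo gives a 32-fold lower number from compound 3 to compound 4 (1.51 log units; beyond the scatter) in this assay and is the first change in the series with a step beyond the scatter. Earlier changes, all on the amide-type nitrogen, gave only floors within the scatter or steps that cannot be read, whereas this aromatic carbon moves the number clearly. Compound 4 also stands clear of the ceiling that still holds compounds 1 and 2: the limit of > 100000 nM in this assay, at which 2 of the 4 values shown sit.

The compounds shown leave open whether the added ring or its acetyl group carries the step. A plain phenyl, an amine or a carboxylic acid at this place would separate the two.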